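The compounds below may be only part of what the source reports. "The series", "measured", "known", "first", "only" and "open" are said of these compounds alone.

Among the compounds with values here, only two compounds have been measured so far. In a physicochemical assay for solubility, read by LC-MS, with a stated time of 16 h, at pH 7 (on this read-out lower numbers stand for lower solubility and higher numbers for higher solubility), compound 1 `COCCC[S+]([O-])c1sc2nc(-c3nccs3)cc(-c3cnc(C)n3C)c2c1N` gives 115 ug/mL while compound 2 `CCCC[S+]([O-])c1sc2nc(-c3nccs3)cc(-c3ccc(COC(=O)CN(C)C)cc3)c2c1N` gives 6 ug/mL on the same scale. Compound 2 therefore holds the lower of the two numbers, and its gap to compound 1 lies beyond the usual scatter of repeated measurements.

The next compound to be read is compound 3 `CCCC[S+]([O-])c1sc2nc(-c3nccs3)cc(-c3ccc(CNC(=O)NCC)cc3)c2c1N` and it departs from compound 2 in one place, a saturated chain carbon bound to an aromatic carbon. The exchange there is (ethylcarbamoyl)amino in place of (((dimethylamino)methyl)carbonyl)oxy on a saturated chain carbon bound to an aromatic carbon and nothing else in the structure changes. Within the data shown here, no measured pair shows this exchange, so the expectation rests only on the change itself and on compound 2 at 6 ug/mL as the starting point. Only a modest fall is expected in this assay and the estimated 2.4-fold lower number from compound 2 to compound 3 (0.38 log units; beyond the scatter) sits close to the edge of the usual scatter, so it could turn out to be no real change at all. Compound 3 is estimated at 2.5 ug/mL with an expected range from 0.6 ug/mL to 9 ug/mL on this read-out.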

Compound 3, solubility: 8.17 ug/mL
Estimate against measurement, compound 3: 3.3-fold (0.51 log units) below; the range from low to high includes it.
By their numbers in this assay, from the lowest: compounds 2 and 3 (each within the scatter of the next); then compound 1.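

In this assay the exchange of (((dimethylamino)methyl)carbonyl)oxy for (ethylcarbamoyl)amino on a saturated chain carbon bound to an aromatic carbon gives a 1.4-fold higher number from compound 2 to compound 3 (0.13 log units; within the scatter) and so leaves the two compounds indistinguishable on this read-out. Within the data shown here, this is the first direct view of this position, and it shows that two rather different groups can sit there with no real separation in the numbers, even though the entering group carries hydrogen-bond donors that the leaving group lacks and the leaving group carries a dimethylamino unit that the entering group does not. Nothing measured here accounts for this outcome.

A single exchange cannot show whether this position is generally indifferent, and a carboxylic acid, a primary amine or a longer alkyl chain on the same saturated carbon could still separate clearly from compound 2 and compound 3. Among these compounds, it also remains open whether (ethylcarbamoyl)amino would give a similarly small step on a compound that differs elsewhere in the structure, since this one pair is the only comparison available.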